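The source may report more compounds than this note shows. Statements on the series, on what has been measured and on what is new or still open speak of the compounds shown alone.

Measured in a physicochemical assay for solubility, read by HPLC, in phosphate buffer, with a stated time of 24 h, at pH 7.4; on this read-out lower numbers stand for lower solubility and higher numbers for higher solubility:
compound 1 `Clc1ccc2c(NCCCCCCCNc3nccc(Cl)n3)ccnc2c1`: 130 nM
compound 2 `Clc1ccc2c(NCCNc3nccc(Cl)n3)ccnc2c1`: 900 nM

Of these two numbers, compound 2 holds the higher at 900 nM, and compound 1 gives 130 nM, with the gap between the two lying beyond the usual scatter. Compound 3 `Clc1ccc2c(NCCNc3ccnc(Cl)n3)ccnc2c1` has the same atoms joined differently: 2-chloropyrimidin-4-yl in place of 4-chloropyrimidin-2-yl on an amine nitrogen. For the measured compounds named here, no measured pair shows this exchange, so the expectation in this assay is for no shift beyond the scatter. The expected change is a 1.1-fold higher number from compound 2 to compound 3 (0.05 log units; within the scatter). For compound 3 the estimated value is 1000 nM, with an expected range of 350 nM to 3000 nM.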

Compound 3, solubility: 680 nM
Estimate against measurement, compound 3: 1.5-fold (0.17 log units) above; the measured number falls inside the stated range.
By their numbers in this assay, from the lowest: compound 1; then compounds 3 and 2 (each within the scatter of the next).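

For the compounds shown here, on an amine nitrogen, 2-chloropyrimidin-4-yl in place of 4-chloropyrimidin-2-yl gives in this assay a 1.3-fold lower number from compound 2 to compound 3 (0.12 log units; within the scatter) as the first reading of this exchange. Swapping these two attachments on the shorter chain therefore leaves the number within the scatter. No measurement at hand gives a reason for this.

Still open, on these data alone, is whether an amine or a methoxy group in place of the chlorine would shift the number. Also open, as far as these compounds go, is whether the same exchange stays within the scatter on the longer chain of compound 1.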